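This account rests on a few compounds, and the source may have more. Where it says the series, first, only, none or still open, it means among the compounds named here.

Compound 2 `CC(C)c1ccc(-c2sc(N)c(C(=O)c3ccc(Cl)cc3)c2CC(C)(C)C)cc1` is tested in an assay on CHO cells for displacement of a labelled ligand from adenosine receptor A1 (Homo sapiens), read by scintillation counting, tested at 10 uM (on this read-out lower numbers stand for less inhibition and higher numbers for more inhibition at the one concentration tested (going by the name of the read-out)), where compound 2 gives 1%. Its closest measured neighbour, compound 1 `CC(C)(C)Cc1c(-c2ccc(Cl)c(Cl)c2)sc(N)c1C(=O)c1ccc(Cl)cc1`, gives 1% in this assay, and the step of no change at the digits printed from compound 1 to compound 2 (within the scatter) shows that exchanging 3,4-dichlorophenyl for 4-isopropylphenyl on the shared core left the inhibition unchanged. Compound 3 `CC(C)(C)Cc1c(Br)sc(N)c1C(=O)c1ccc(Cl)cc1` differs from compound 2 by bromo in place of 4-isopropylphenyl on an aromatic carbon. Among the measured compounds shown here, no measured step covers a change of this kind, and both measured compounds sit at the very bottom of the inhibition scale, so the expectation for compound 3 is a step of a number 1 percentage points higher from compound 2 to compound 3 (within the scatter), that is, no change beyond the scatter. Compound 3 is therefore estimated at 2%, within a range from -5% to 12%.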

Compound 3, a percentage reported as inhibition, at one concentration (the size of the read-out at that concentration, not a potency): 1%
Compound 3: middle estimate off by 1 percentage points, on the high side; the range from low to high includes it.
By their numbers in this assay, from the lowest: compounds 1, 2 and 3 (each within the scatter of the next).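

In this assay, swapping the 4-isopropylphenyl for bromo gives no change at the digits printed from compound 2 to compound 3 (within the scatter) and swapping the 3,4-dichlorophenyl for bromo gives no change at the digits printed from compound 1 to compound 3 (within the scatter) on the same shared core. At this place next to the ring sulfur, then, a lone bromo reads the same as either substituted phenyl, so the six-membered aromatic ring can go without any shift in this read-out, though all three compounds sit at the bottom of the scale. Nothing available explains this flat result.

As far as these compounds go, whether an amine or a carboxylic acid at this place would lift the inhibition stays open. So does whether replacing the neopentyl group or the (4-chlorophenyl)carbonyl group would do so.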